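The source may report more compounds than this note shows. Statements on the series, on what has been measured and on what is new or still open speak of the compounds shown alone.

Compound 1, `COc1cc(N2C(N)=C(C#N)C(/C=C/c3ccccc3)C3=C2CC(C)(C)CC3=O)cc(OC)c1OC`, gives 30% in a functional assay on Ehrlich cells (Mus musculus) for cytotoxicity, tested at 50 ug/mL; on this read-out lower numbers stand for a weaker effect and higher numbers for a stronger effect at the one concentration tested. Compound 2, `COc1cc(N2C(N)=C(C#N)C(c3cccc([N+](=O)[O-])c3)C3=C2CC(C)(C)CC3=O)cc(OC)c1OC`, gives 30% in the same assay, and the step of no change at the digits printed from compound 1 to compound 2 (within the scatter) shows no change within the scatter. Compound 1 thus stands level with compound 2 at the digits shown; nothing among the measured compounds separates the two.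

Compound 3, `COc1ccccc1C1C(C#N)=C(N)N(c2cc(OC)c(OC)c(OC)c2)C2=C1C(=O)CC(C)(C)C2`, has not been tested. Its change from compound 1 is 2-methoxyphenyl in place of 2-phenylethenyl on a saturated ring carbon. Among the compounds with values here, the only measured step that bears on it, no change at the digits printed from compound 1 to compound 2 (within the scatter), likewise exchanged the 2-phenylethenyl group on that saturated ring carbon for a six-membered aromatic ring of carbon only and left the read-out unchanged. On that basis the step of no change at the digits printed from compound 1 to compound 3 (within the scatter) is expected to stay within the scatter, in no particular direction. Compound 3 is therefore estimated at 30%, with a range from 15% to 45%.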

Compound 3, a percentage reported as activity, at one concentration (the size of the read-out at that concentration, not a potency): 70%
Estimate against measurement, compound 3: 40 percentage points below, and the stated range ends below it.
By their numbers in this assay, from the lowest: compounds 1 and 2 (each within the scatter of the next); then compound 3.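

In this assay, the saturated ring carbon proves sensitive to the group it carries: 2-methoxyphenyl gives a number 40 percentage points higher from compound 1 to compound 3 (beyond the scatter) and also a number 40 percentage points higher from compound 2 to compound 3 (beyond the scatter). The level pair of compounds had hinted at a place that tolerates exchange, but compound 2 and compound 3 both carry a six-membered aromatic ring of carbon only at this carbon and still lie far apart, so the presence of that ring alone does not set the read-out. Nothing available explains why the 2-methoxyphenyl group stands apart.

Going by these compounds, it remains open whether the methoxy group itself matters or whether a hydroxyl group, an ethoxy group or a chlorine atom in its place would give the same read-out. Equally open, on these data alone, is what a plain phenyl group would give at this carbon.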